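Ethyl for tert-butyl: expected cytotoxicity of compound 4

The source may report more compounds than this note shows. Statements on the series, on what has been measured and on what is new or still open speak of the compounds shown alone.

Compound 1 `CCCCCCCCCCSc1ncnc2c1ncn2CC(=O)OC(C)(C)C` gives > 10 ug/mL (a limit)
Compound 2 `CC(C)Oc1nc(Cl)nc2[nH]cnc12` gives "not determined" (no result reported)
Compound 3 `Nc1nc(OCc2ccc(Cl)c(Cl)c2)c2nc[nH]c2n1` gives "not determined" (no result reported)

All three entries belong to an ADME assay on Vero cells (Chlorocebus sabaeus) for cytotoxicity; on this read-out lower numbers stand for higher toxicity in this test and higher numbers for lower toxicity in this test. Compound 1 records > 10 ug/mL, which is a limit of the assay and not a number. The series therefore has a single anchor: the limit of > 10 ug/mL in this assay, at which 1 of the 3 values shown sits. Compound 2 and compound 3 add no number to it.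

Compound 4 `CCCCCCCCCCSc1ncnc2c1ncn2CC(=O)OCC` awaits measurement in this assay. It keeps the core of compound 1 and differs in one group: ethyl in place of tert-butyl on an oxygen next to a carbonyl group. This places ethyl in place of tert-butyl on an oxygen next to a carbonyl group.

Going by the values given here, no measured pair shows what this exchange does, so no change beyond the usual scatter is expected. The expected step that the limit leaves unreadable from compound 1 to compound 4 is small and has no settled direction. The expectation rests on compound 1 alone, with its limit of > 10 ug/mL. A further report of only a limit is the more likely outcome for the new measurement. Compound 4 is estimated at 15 ug/mL, with an expected range from 5 ug/mL to 50 ug/mL.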

Compound 4, half-maximal cytotoxic concentration: > 62.5 ug/mL
Compound 4: a limit, no number; the forecaster's own chance of this, stated with the estimate: 60%; middle value at least 4.1-fold (0.61 log units) from the limit.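

Compound 1 and compound 4 both stand only as limits in this assay, not as numbers, so no step can be read for ethyl in place of tert-butyl on an oxygen next to a carbonyl group. The compounds shown leave open whether this exchange shifts the read-out in this assay at all, and in which direction.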